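This account rests on a few compounds, and the source may have more. Where it says the series, first, only, none or still open, it means among the compounds named here.

Working notes on the series. Compound 1 `Cc1ccc2c(c1)CCCN2c1nc(Cl)nc2ccccc12` and compound 2 `Cc1ccc2c(c1)CCCN2c1nc(C)nc2ccccc12` share one core and differ in a single place. In a functional assay on DU-145 cells (Homo sapiens) for cytotoxicity, read by sulforhodamine B assay (a lower number here means a stronger inhibitor of growth, a higher number a weaker inhibitor of growth), compound 1 gives 57 nM, and compound 2 gives 187 nM. The change between them is methyl in place of chloro on an aromatic carbon and the step it made was a 3.3-fold higher number from compound 1 to compound 2 (0.52 log units; beyond the scatter).

Compound 3 `COc1ccc2c(c1)CCN2c1nc(Cl)nc2ccccc12` carries a different core, and the difference between the core of compound 3 and the core of compound 1 is not broken down here. In this assay compound 3 gives 165 nM. That number sits within the scatter of compound 2, while compound 1 gives the lower number of that pair by a margin beyond the scatter.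

Compound 4 `COc1ccc2c(c1)CCN2c1nc(C)nc2ccccc12` is not yet measured. It stands to compound 3 as compound 2 stands to compound 1: the change is methyl in place of chloro on an aromatic carbon, the same change at the same kind of place, this time made on the core of compound 3. For the measured compounds named here, the only guide for this change is the one measured occurrence, so the expectation is that the second occurrence behaves like the first. Going by the values given here, the step expected in this assay is a 3.3-fold higher number from compound 3 to compound 4 (0.51 log units; beyond the scatter), set beside the earlier 3.3-fold higher number from compound 1 to compound 2 (0.52 log units; beyond the scatter) because a 3.3-fold higher number from compound 1 to compound 2 (0.52 log units; beyond the scatter) is the single measured instance of this change. For compound 4 the estimate in this assay is therefore 540 nM. The range expected for compound 4 runs from an estimated 250 nM to an estimated 1200 nM. Whether the change carries over from one core to the other is what the measurement of compound 4 will show.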

Compound 4, concentration for 50% growth inhibition: 243 nM
Compound 4: the middle estimate sits 2.2-fold (0.35 log units) above what was measured; the whole stated range lies above it.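

On the second core, methyl in place of chloro on the aromatic carbon between the two ring nitrogen atoms gives a 1.5-fold higher number from compound 3 to compound 4 (0.17 log units; within the scatter) in this assay, so on this core the effect of the change cannot be separated from the usual scatter of repeated measurements. Set beside the single earlier occurrence, the new step does not depart from it by more than two such steps can scatter, so the data give no sign that the two cores respond differently: the same change on two cores in this assay, a 3.3-fold higher number (0.52 log units; beyond the scatter) from compound 1 to compound 2 and a 1.5-fold higher number (0.17 log units; within the scatter) from compound 3 to compound 4, 2.2-fold (0.35 log units) apart, within the scatter of two such steps

This does not show that the change has one shared size on both cores, since one step lies beyond the scatter and the other within it, and a single pair on each core can establish neither a common size nor a size that depends on the core.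

The compounds shown leave open how other groups at this place would behave, such as an amine, a nitrile or a longer chain like ethyl, since only chloro and methyl appear there. They also leave open which part of the difference between the core of compound 1 and the core of compound 3 matters, if any does, as those two cores differ by more than one feature.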